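From Nitro to Chloro on a Phenyl Ring

A few compounds are considered here, and "the series" means these few. Any claim that something is new, unique, unknown or untested is made for them only; others in the source may bear on it.

Of the compounds shown here, three have so far been tested in a functional assay on HT-29 cells (Homo sapiens) for antiproliferative activity, read by MTT assay, with a stated time of 96 h; a higher number here means a weaker inhibitor, a lower number a stronger inhibitor. Compound 1 `O=C1C2=C(C(=O)c3ncccc31)C1(CS2)NC(=O)N(c2ccc(Cl)cc2)C1=O` gives 2 nM. Compound 2 `O=C1NNC(=O)C2(CSC3=C2C(=O)c2ncccc2C3=O)N1` gives 1580 nM; 1600 nM; 1600 nM (3 entries), and its repeated measurements agree closely. Compound 3 `O=C1NN(c2ccc([N+](=O)[O-])cc2)C(=O)C2(CSC3=C2C(=O)c2ncccc2C3=O)N1` gives 1010 nM. This puts compound 3 within the usual scatter of compound 2, so the two cannot be ranked, while the number for compound 3 lies far above that of compound 1, well beyond the scatter.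

Compound 4 `O=C1NN(c2ccc(Cl)cc2)C(=O)C2(CSC3=C2C(=O)c2ncccc2C3=O)N1` has not yet been measured. It differs from compound 3 in one place, with chloro in place of nitro on an aromatic carbon, para to a large group, so that 4-nitrophenyl becomes 4-chlorophenyl (chloro in place of nitro on an aromatic carbon).

Within the data shown here, no measured pair shows this change directly, so any expectation is indirect. Compound 1 carries the same 4-chlorophenyl group on a different core and gives 2 nM, which points towards a lower number. However, compound 3 shares its core with compound 2, so only part of that large gap should carry over. A moderate move towards a lower number is expected, estimated as a 5.1-fold lower number from compound 3 to compound 4 (0.70 log units; beyond the scatter). The estimated value for compound 4 is 200 nM, with an expected range of 30 nM to 1200 nM.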

Compound 4, half-maximal inhibitory concentration: 220 nM
Beside the measured number, compound 4's estimate is 1.1-fold (0.04 log units) below it; the range from low to high includes it.
By their numbers in this assay, from the lowest: compound 1; then compound 4; then compound 3.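

Among these compounds, the step of a 4.6-fold lower number from compound 3 to compound 4 (0.66 log units; beyond the scatter) is the first measured between two compounds that differ in one place. It shows that, on this shared core, the group on the aromatic carbon para to a large group has a real influence on the number, since going from 4-nitrophenyl to 4-chlorophenyl moves it beyond the usual scatter, though only modestly. The repeats on this core lend that modest step some weight, as they stay close together: the several entries of compound 2 in this assay, 1580 nM; 1600 nM; 1600 nM (3 entries)

From the compounds shown here alone, what remains open is which part of the exchange matters, since this one pair swaps a nitro group of three heavy atoms with two hydrogen-bond acceptors for a single chlorine with none, and it cannot separate those differences from one another. Other groups at the same place, such as a methoxy group, an amine, a fluorine or a bromine, would be needed to show whether the trend belongs to chloro alone or extends to a wider set of substituents on this phenyl ring.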